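Propoxymethyl for azido on the shared core

The source may report more compounds than this note shows. Statements on the series, on what has been measured and on what is new or still open speak of the compounds shown alone.

Compound 1 `[N-]=[N+]=Nc1c(F)c(N)c2c(=O)cc(-c3ccc(N)c(F)c3)oc2c1F` stands highest of the two numbers given in a functional assay on MCF7 cells (Homo sapiens) for cytotoxicity, read by neutral red uptake, with a stated time of 3 days; on this read-out lower numbers stand for stronger inhibition and higher numbers for weaker inhibition; in it compound 1 gives 460 nM. Compound 2 `CCCCCCCCCC(=O)OCc1c(F)c(N)c2c(=O)cc(-c3ccc(N)c(F)c3)oc2c1F` gives 100 nM in this assay. Compound 3 `CCCCCCCCCCCCCCCCCC(=O)OCc1c(F)c(N)c2c(=O)cc(-c3ccc(N)c(F)c3)oc2c1F` reaches only the limit of > 10000 nM in this assay. Going by the values given here, the one measured step, an at least 100-fold higher number from compound 2 to compound 3 (2.00 log units; beyond the scatter), concerns a chain at a different position and sits at the limit of > 10000 nM in this assay, at which 1 of the 3 values shown sits. Compound 4 `CCCOCc1c(F)c(N)c2c(=O)cc(-c3ccc(N)c(F)c3)oc2c1F` differs from compound 1 by propoxymethyl in place of azido on an aromatic carbon. Among the compounds with values here, no measured step addresses that exchange; the small group entering here is unlike the long chain of compound 3. The expected outcome is a step of a 1.3-fold lower number from compound 1 to compound 4 (0.12 log units; within the scatter), within the scatter. Compound 4 is therefore estimated at 350 nM, between 100 nM and 1500 nM.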

Compound 4, half-maximal inhibitory concentration: 1200 nM
Compound 4: middle estimate off by 3.4-fold (0.54 log units), on the low side; the measured number falls inside the stated range.
By their numbers in this assay, from the lowest: compound 2; then compound 1; then compound 4. At a limit, above all of these: compound 3.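

Propoxymethyl in place of azido on this aromatic carbon moves the number in this assay, giving a 2.6-fold higher number from compound 1 to compound 4 (0.42 log units; beyond the scatter). Propyl in place of nonylcarbonyl on the oxygen gives a 12-fold higher number from compound 2 to compound 4 (1.08 log units; beyond the scatter), the first reading of a short group on this arm, and this step is larger than the step from the azido compound. Nothing measured here accounts for either step.

Going by these compounds, whether the carbonyl or the chain length carries the step from the ester remains open. So does the effect of a decyl ether or a carboxylic acid at this carbon.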